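A few compounds are considered here, and "the series" means these few. Any claim that something is new, unique, unknown or untested is made for them only; others in the source may bear on it.

Working notes on the series. For the measured compounds named here, in a functional assay on L02 cells (Homo sapiens) for inhibition, read by Griess assay, with stated times of 1 h and 24 h (on this read-out higher numbers stand for weaker inhibition and lower numbers for stronger inhibition), compound 1 `CCCc1nn(C)c2c(NC(C)C)nc(CCc3cccnc3)nc12` gives 514000 nM, the only true number so far.

Compound 2 `COc1cc(/C=C/c2nccc(NC(C)C)n2)cc(OC)c1OC` stands at < 40000 nM, which is a limit of the assay and not a number. Any comparison with compound 2 therefore starts from a bound, not a fixed point. Going by the values given here, compound 1 and compound 2 also differ in more than one place, so no measured single-change step is available to calibrate the next one.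

The next compound is compound 3 `COc1cc(/C=C/c2nc(Cl)cc(NC(C)C)n2)cc(OC)c1OC`, which carries chloro in place of hydrogen on an aromatic carbon. The rest of the structure of compound 2 is kept, including the isopropylamino group. Among the compounds with values here, with no measured precedent for this change, the working expectation in this assay is no shift beyond the usual scatter, and no direction is favoured. The expected change is a step that the limit leaves unreadable from compound 2 to compound 3, and it is uncertain because the starting point is only a limit.

Compound 3 is estimated at 20000 nM, with an expected range of 4000 nM to 70000 nM.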

Compound 3, half-maximal inhibitory concentration: < 40000 nM
Compound 3 was reported as a limit; the forecaster's own chance of this, stated with the estimate: 35%; the middle value does not contradict the limit.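

No step can be read from compound 2 to compound 3 in this assay, because both compounds are reported only as the same limit of the assay, not as numbers: the limit of < 40000 nM in this assay, at which 2 of the 3 values shown sit.

The compounds shown leave open whether chloro in place of hydrogen on an aromatic carbon shifts inhibition at all, and in which direction.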